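This account rests on a few compounds, and the source may have more. Where it says the series, first, only, none or still open, it means among the compounds named here.

Measured in an ADME assay on the whole organism (strain FVB) for pharmacokinetics, with Mus musculus as the target, read by LC-MS, at a dose of 30 mg/kg by the oral route; a higher number here means more compound in the circulation at the dose given, a lower number less compound in the circulation:
compound 1, `CC(C)(O)CN1CCC(Oc2ccc([C@H]3CC[C@]4(CC3)OOC3(O4)C4CC5CC(C4)CC3C5)cc2)CC1`: 14200 ng.h/mL
compound 2, `c1cc([C@H]2CC[C@]3(CC2)OOC2(O3)C3CC4CC(C3)CC2C4)ccc1OCCC1CCNCC1`: 16000 ng.h/mL
compound 3, `N[C@H]1CC[C@@H](Oc2ccc([C@H]3CC[C@]4(CC3)OOC3(O4)C4CC5CC(C4)CC3C5)cc2)CC1`: 13400 ng.h/mL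

Compound 1 sits among the three with steps a 1.1-fold higher number from compound 1 to compound 2 (0.05 log units; within the scatter) and a 1.1-fold lower number from compound 1 to compound 3 (0.03 log units; within the scatter), both inside the scatter, so no order can be read from these numbers. Compound 4, `CC1(C)CC(O)(COc2ccc([C@H]3CC[C@]4(CC3)OOC3(O4)C4CC5CC(C4)CC3C5)cc2)CC(C)(C)N1`, remains to be measured. Its change from compound 1 is (4-hydroxy-2,2,6,6-tetramethylpiperidin-4-yl)methyl in place of 1-(2-hydroxy-2-methylpropyl)piperidin-4-yl on an oxygen on an aromatic ring. Every earlier exchange at the same oxygen, including a 1.2-fold lower number from compound 2 to compound 3 (0.08 log units; within the scatter), shifted the number by less than the scatter, and all three measured compounds differ only at this position. The step of a 1.1-fold lower number from compound 1 to compound 4 (0.04 log units; within the scatter) is therefore expected to stay within the scatter. Compound 4 is estimated at 13000 ng.h/mL, with a range from 6000 ng.h/mL to 28000 ng.h/mL.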

Compound 4, area under the concentration-time curve: 17300 ng.h/mL
Compound 4: the middle estimate sits 1.3-fold (0.12 log units) below what was measured, and the stated range covers the measured number.
By their numbers in this assay, from the lowest: compounds 3, 1, 2 and 4 (each within the scatter of the next).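

In this assay the (4-hydroxy-2,2,6,6-tetramethylpiperidin-4-yl)methyl group on this oxygen stays within the scatter of all three earlier compounds (a 1.2-fold higher number from compound 1 to compound 4 (0.09 log units; within the scatter)) (a 1.3-fold higher number from compound 3 to compound 4 (0.11 log units; within the scatter)) (a 1.1-fold higher number from compound 2 to compound 4 (0.03 log units; within the scatter)). The position on an oxygen on an aromatic ring therefore accepts a fourth group, one with a heavily substituted ring and a ring hydroxyl, with no readable difference in the number. Nothing at hand accounts for this flat picture. Going by these compounds, all four groups carry an amine, so a carboxylic acid or a neutral amide at this oxygen remains open. So does any group that would take the number beyond the scatter.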